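Replacing cyclohexylmethyl with a substituted pyridine

This account rests on a few compounds, and the source may have more. Where it says the series, first, only, none or still open, it means among the compounds named here.

In a functional assay on Jurkat cells (Homo sapiens) (on this read-out lower numbers stand for stronger inhibition and higher numbers for weaker inhibition), compound 1 `C[C@H](NC(=O)C(=O)NCc1ccc(Cl)cc1)C(=O)N[C@@H](CC(=O)O)C(=O)COc1c(F)c(F)cc(F)c1F` gives 8.4 nM, compound 2 `C[C@H](NC(=O)C(=O)NCCC1CCCC1)C(=O)N[C@@H](CC(=O)O)C(=O)COc1c(F)c(F)cc(F)c1F` gives 11 nM, and compound 3 `C[C@H](NC(=O)C(=O)NCC1CCCCC1)C(=O)N[C@@H](CC(=O)O)C(=O)COc1c(F)c(F)cc(F)c1F` gives 19 nM. These three share a core and differ only in the group carried on an amide-type nitrogen. Two steps place compound 3 among them: a 1.7-fold higher number from compound 2 to compound 3 (0.24 log units; within the scatter) and a 2.3-fold higher number from compound 1 to compound 3 (0.35 log units; beyond the scatter). The third step is a 1.3-fold higher number from compound 1 to compound 2 (0.12 log units; within the scatter).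

The next structure, compound 4 `C[C@H](NC(=O)C(=O)Nc1cccnc1N(C)C)C(=O)N[C@@H](CC(=O)O)C(=O)COc1c(F)c(F)cc(F)c1F`, changes that same group: 2-(dimethylamino)pyridin-3-yl in place of cyclohexylmethyl on an amide-type nitrogen. In words, 2-(dimethylamino)pyridin-3-yl stands in place of cyclohexylmethyl on an amide-type nitrogen. Among the measured compounds shown here, no measured compound carries this group, so the three steps offer only indirect guidance. All of them are small, which suggests a modest change rather than a large one. For the measured compounds named here, compound 1, the only measured compound with an aromatic ring in this group, gives 8.4 nM, so a slightly lower number is expected. The estimated change is a 1.4-fold lower number from compound 3 to compound 4 (0.13 log units; within the scatter), a step not expected to exceed the scatter. In this assay, the expected value for compound 4 is 14 nM, within an estimated range of 4 nM to 50 nM.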

Compound 4, half-maximal inhibitory concentration: 27 nM
Beside the measured number, compound 4's estimate is 1.9-fold (0.29 log units) below it, and the stated range covers the measured number.
By their numbers in this assay, from the lowest: compounds 1, 2, 3 and 4 (each within the scatter of the next, the first and the last beyond it).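

In this assay, an aromatic ring carried directly on the amide-type nitrogen gives a number close to that of the saturated cyclohexylmethyl group (a 1.4-fold higher number from compound 3 to compound 4 (0.15 log units; within the scatter)). Having an aromatic ring is not enough to match compound 1, though, since the 2-(dimethylamino)pyridin-3-yl group falls short of the 4-chlorobenzyl group by a step beyond the scatter (a 3.2-fold higher number from compound 1 to compound 4 (0.51 log units; beyond the scatter)). It also falls short of the 2-cyclopentylethyl group by a step beyond the scatter (a 2.5-fold higher number from compound 2 to compound 4 (0.39 log units; beyond the scatter)), and no measurement shown accounts for these differences.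

The compounds shown leave open which part of the new group matters: the dimethylamino group, the pyridine nitrogen, or the absence of a carbon chain on the ring. A plain phenyl or a pyridin-3-ylmethyl group on that nitrogen would help separate these.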